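The compounds below may be only part of what the source reports. "The series", "measured", "known", "first", "only" and "open" are said of these compounds alone.

Among the measured compounds shown here, in a functional assay on the whole organism with Rattus norvegicus as the target (on this read-out higher numbers stand for an effect only at larger amounts of compound and lower numbers for an effect already at smaller amounts), compound 1 `O=C(O)C(=O)Nc1nc(-c2cc(CO)no2)cs1` gives 0.007 mg/kg as its only number, and one further entry for it carries no single number. Compound 3 `O=C(O)C(=O)Nc1nc(-c2cc(-c3c(F)cccc3Cl)no2)cs1` has 2-chloro-6-fluorophenyl in place of hydroxymethyl on an aromatic carbon. For the measured compounds named here, no measured step isolates this change. The nearest guide is compound 2 `O=C(O)C(=O)Nc1nc(-c2cc(-c3ccccc3)no2)cs1` which also has a six-membered aromatic ring of carbon only at that place and gives 0.24 mg/kg; 0.24 mg/kg (2 entries) as a larger dose than compound 1 shows. A clear move toward larger doses is therefore expected (a 14-fold higher number from compound 1 to compound 3 (1.15 log units; beyond the scatter)). Compound 3 is estimated at about 0.1 mg/kg with an expected range running from 0.02 mg/kg up to 0.5 mg/kg overall.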

Compound 3, dose for half-maximal effect: 2.4 mg/kg
For compound 3 the middle estimate is 24-fold (1.38 log units) below the measured one, outside the stated range (above it).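

In this assay, 2-chloro-6-fluorophenyl in place of hydroxymethyl on this aromatic carbon brings a 340-fold higher number from compound 1 to compound 3 (2.54 log units; beyond the scatter), so the dose depends strongly on what this position carries. The printed values also separate the two aromatic rings: compound 2 gives 0.24 mg/kg; 0.24 mg/kg (2 entries), while compound 3 gives 2.4 mg/kg. No measured evidence accounts for the size of this step.

From the compounds shown here alone, whether an aminomethyl group or a carboxylic acid at this place would stay near compound 1 remains open. So does the separate share of the chlorine and the fluorine.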